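The source may report more compounds than this note shows. Statements on the series, on what has been measured and on what is new or still open speak of the compounds shown alone.

Going by the values given here, in an ADME assay on Caco-2 cells (Homo sapiens) for permeability, read by LC-MS, in the apical to basolateral direction, with a stated time of 60 min, at pH 6.5 (on this read-out lower numbers stand for lower permeability and higher numbers for higher permeability), three compounds have numbers so far. Compound 3 `O=C(NCc1cc(Cl)ccc1-n1cnnn1)[C@@H]1C[C@H]2C[C@H]2N1C(=O)[C@H](O)CC1CC1` gives 6.9 10^-6 cm/s on this read-out, and compound 1 `O=C(NCc1cc(Cl)ccc1-n1cnnn1)[C@@H]1C[C@@H]2C[C@@H]2N1C(=O)[C@H](O)CC1CC1` gives 3.6 10^-6 cm/s within the usual scatter of it. Compound 2 `O=C(O[C@@H](C(=O)N1N=CC[C@H]1C(=O)NCc1cc(Cl)ccc1-n1cnnn1)c1ccc(F)cc1)c1ccccc1` gives 43 10^-6 cm/s on the same scale, a number clearly higher than those of the other two.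

The next compound, compound 4 `O=C(NCc1cc(Cl)ccc1-n1cnnn1)[C@@H]1C[C@H]2C[C@H]2N1C(=O)[C@H](O)c1ccccc1`, differs from compound 3 in one place: phenyl in place of cyclopropylmethyl on a saturated chain carbon bound to a carbonyl carbon and an oxygen on a saturated carbon is the whole change.

Among the compounds with values here, the one measured step between close relatives is a 1.9-fold higher number from compound 1 to compound 3 (0.28 log units; within the scatter) and it stays within the scatter. That pair shows the fact that compounds 1 and 3 differ only in the configuration as drawn and so gives no size for a swap of this group. Within the data shown here, compound 2 differs from compound 3 in more than one place, so it sets no step here either.

With compound 3 at 6.9 10^-6 cm/s as the starting point, no shift beyond the scatter is expected in this assay for this swap. The estimated change is a 1.0-fold higher number from compound 3 to compound 4 (0.01 log units; within the scatter) and it is a small one. For compound 4 the expected value is 7 10^-6 cm/s with an estimated range from 3 10^-6 cm/s to 16 10^-6 cm/s on the same scale.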

Compound 4, apparent permeability: 17 10^-6 cm/s
Compound 4: the middle estimate sits 2.4-fold (0.39 log units) below what was measured; the measured number lies above the stated range.
By their numbers in this assay, from the lowest: compounds 1 and 3 (each within the scatter of the next); then compound 4; then compound 2.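

In this assay, placing phenyl in place of cyclopropylmethyl on a saturated chain carbon bound to a carbonyl carbon and an oxygen on a saturated carbon gives a 2.5-fold higher number from compound 3 to compound 4 (0.39 log units; beyond the scatter), a modest step but the only one among these close relatives that lies beyond the scatter. This shows that the group at this place can move the number, something the earlier pair could not show: a 1.9-fold higher number from compound 1 to compound 3 (0.28 log units; within the scatter) stays within the scatter, and it concerns configuration alone, with this group unchanged. Nothing shown here gives a reason for the rise.

The compounds leave open whether the rise goes with the aromatic ring or simply with a six-membered ring and its larger number of heavy atoms, a question that a cyclohexyl group at the same place would help to settle. Also open, going by these compounds, is how a ring containing nitrogen, such as pyridyl, or a chain ending in a carboxylic acid would read at this place, and whether the same swap gives a similar step on the core of compound 1.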